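Benzyl-ring substituent survey in the HEK-293T cytotoxicity read-out

The compounds below may be only part of what the source reports. "The series", "measured", "known", "first", "only" and "open" are said of these compounds alone.

Measured compounds:
- compound 1 `Cn1cc(SCc2nnc(SCc3ccccc3C#N)n2-c2c(Cl)cccc2Cl)c2ccccc21` gives 78600 nM in a toxicity assay on HEK-293T cells (Homo sapiens) for cytotoxicity, read by CCK-8 assay, with a stated time of 48 h; on this read-out higher numbers stand for lower toxicity in this test and lower numbers for higher toxicity in this test
- compound 2 `Cn1cc(SCc2nnc(SCc3c(Cl)cccc3Cl)n2-c2c(Cl)cccc2Cl)c2ccccc21` reaches only the assay limit, > 100000 nM, in this assay
- compound 3 `Cn1cc(SCc2nnc(SCc3ccc(Cl)cc3F)n2-c2c(Cl)cccc2Cl)c2ccccc21` gives 87300 nM in this assay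

All three share one core and differ only in the aryl group on the saturated chain carbon bound to a sulfur. The steps among them are small: an at least 1.2-fold higher number from compound 1 to compound 2 (0.10 log units; that floor lies within the scatter), a 1.1-fold higher number from compound 1 to compound 3 (0.05 log units; within the scatter) and an at least 1.1-fold lower number from compound 2 to compound 3 (0.05 log units; that floor lies within the scatter). Compound 3 sits within the scatter of compound 1; the remaining value is a limit, (the limit of > 100000 nM in this assay, at which 1 of the 3 values shown sits).

Compound 4 `Cn1cc(SCc2nnc(SCc3ccc(Cl)cc3C(F)(F)F)n2-c2c(Cl)cccc2Cl)c2ccccc21` is not yet measured. Its change from compound 3 is trifluoromethyl in place of fluoro on an aromatic carbon. Within the data shown here, no measured step covers this exact exchange; the closest comparisons are the aryl swaps above, none of which moved this assay beyond the scatter. The step of a 1.0-fold higher number from compound 3 to compound 4 (0.01 log units; within the scatter) is therefore expected to stay within the scatter. For compound 4 the estimate is 90000 nM, with a range from 50000 nM to 200000 nM, and a real chance that only a limit is reported.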

Compound 4, half-maximal cytotoxic concentration: 56500 nM
For compound 4 the middle estimate is 1.6-fold (0.20 log units) above the measured one; low and high end bracket the measured number.
By their numbers in this assay, from the lowest: compounds 4, 1 and 3 (each within the scatter of the next). At a limit, above all of these: compound 2.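

In this assay, trifluoromethyl in place of fluoro on the aromatic carbon ortho to a large group brings four heavy atoms where one stood, yet gives a 1.5-fold lower number from compound 3 to compound 4 (0.19 log units; within the scatter), the first exchange shown within a single substituent of the benzyl ring rather than of the whole aryl group. The wider comparisons agree as far as they can be read: a 1.4-fold lower number from compound 1 to compound 4 (0.14 log units; within the scatter), and an at least 1.7-fold lower number from compound 2 to compound 4 (0.24 log units; that floor lies within the scatter), so no readable step among these four compounds passes beyond the scatter. The one compound without a number is compound 2, whose value is a limit: the limit of > 100000 nM in this assay, at which 1 of the 4 values shown sits.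

Still open, going by these compounds, is whether an amine or a carboxylic acid on this aromatic carbon would move the read-out beyond the scatter. Equally open, on these data alone, is whether a longer chain in place of the saturated chain carbon bound to the sulfur would do so.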